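The compounds below may be only part of what the source reports. "The series", "measured", "known", "first", "only" and "open" are said of these compounds alone.

Three members of one series have been tested in a functional assay on the whole organism (artery, strain albino) with Rattus norvegicus as the target, with a stated time of 720 min, at a dose of 10 mg/kg by the oral route (a higher number here means more inhibition at the dose given (going by the name of the read-out), a lower number less inhibition), and a fourth awaits the same measurement. Compound 1 `COc1ccc(C2N=C(SCc3ccccc3)NC(C)=C2C(=O)Nc2ccc(F)cc2)cc1OC` gives 1.5% in this assay. Compound 2 `COc1ccc(C2N=C(SCc3ccc(Cl)cc3)NC(C)=C2C(=O)Nc2ccc(F)cc2)cc1OC` gives 22.2%, and the step of a number 20.7 percentage points higher from compound 1 to compound 2 (beyond the scatter) rests on a single change, (chloro in place of hydrogen on an aromatic carbon). Compound 3 `CC1=C(C(=O)Nc2ccc(F)cc2)C(c2ccc([N+](=O)[O-])cc2)N=C(SCc2ccccc2)N1` gives 27.3%; the change 4-nitrophenyl in place of 3,4-dimethoxyphenyl on a saturated ring carbon carries the step of a number 25.8 percentage points higher from compound 1 to compound 3 (beyond the scatter). Compounds 2 and 3 differ from each other in two places, and their values in this assay lie within the scatter of each other.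

Compound 4 `CC1=C(C(=O)Nc2ccc(F)cc2)C(c2ccc([N+](=O)[O-])cc2)N=C(SCc2ccccc2Cl)N1` is the unmeasured member. It differs from compound 3 by chloro in place of hydrogen on an aromatic carbon. The same kind of change, though not the same one, has been made once before, from compound 1 to compound 2: there the chloro enters para to a large group, whereas in compound 4 it enters ortho to a large group. Among the measured compounds shown here, how far the one earlier step, a number 20.7 percentage points higher from compound 1 to compound 2 (beyond the scatter), transfers to a different core and a different place on the ring cannot be read from these three numbers alone. With a single precedent at a different place, compound 4 is expected to gain less than that earlier step, an estimated a number 7.7 percentage points higher from compound 3 to compound 4 (within the scatter). The value expected for compound 4 in this assay is therefore 35%, with a plausible range from 15% to 55%.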

Compound 4, a percentage reported as inhibition, in the whole organism at one dose (the size of the read-out at that dose, not a potency): 13.9%
Estimate against measurement, compound 4: 21.1 percentage points above; measured number outside the range, below it.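

On the core of compound 3, chloro in place of hydrogen on an aromatic carbon, ortho to a large group, gives a number 13.4 percentage points lower from compound 3 to compound 4 (beyond the scatter) in this assay, so the direction of the earlier gain does not hold on this core. Set side by side, the two steps show that this change cannot be carried from one core to the other in this series as a fixed increment: the same change on two cores in this assay, a number 20.7 percentage points higher (beyond the scatter) from compound 1 to compound 2 and a number 13.4 percentage points lower (beyond the scatter) from compound 3 to compound 4, 34.1 percentage points apart, beyond the scatter of two such steps. They do not show why, since the core and the place of the chloro on the ring both differ between the two steps, each step rests on one pair of compounds, and these numbers cannot separate the part played by the core from the part played by the place.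

The compounds shown leave open how chloro behaves on the core of compound 3 at the place it holds in compound 2, and on the core of compound 1 at the place it holds in compound 4, the two pairings that would separate core from place. They also leave open whether a methyl or bromo group on the same carbon, or an amine in place of the benzylsulfanyl group, would follow the chloro in this assay.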